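Working notes: a second methyl on compound 3

The source may hold more compounds than are shown below. What is called first, only, known or untested is meant among the compounds shown, and "the series" means these compounds.

Measured in a functional assay on HCT-116 cells (Homo sapiens) for inhibition, read by CCK-8 assay, with a stated time of 48 h; on this read-out lower numbers stand for stronger inhibition and higher numbers for weaker inhibition:
- compound 1 `COc1cc(-c2ccnc3cc(-c4ccc(F)cc4)nn23)cc(OC)c1OC`: 5030 nM
- compound 2 `COc1cc(-c2ccnc3cc(-c4ccc(Cl)cc4)nn23)cc(OC)c1OC`: 3340 nM
- compound 3 `COc1cc(-c2ccnc3cc(-c4ccc(C)cc4)nn23)cc(OC)c1OC`: 48 nM

Of these three, compound 3 gives the lowest number, 48 nM. The next step leads to compound 4 `COc1cc(-c2ccnc3cc(-c4ccc(C)c(C)c4)nn23)cc(OC)c1OC`, with methyl in place of hydrogen on an aromatic carbon. The group changes from 4-methylphenyl to 3,4-dimethylphenyl.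

The closest evidence is a 100-fold lower number from compound 1 to compound 3 (2.02 log units; beyond the scatter) and a 70-fold lower number from compound 2 to compound 3 (1.84 log units; beyond the scatter). Both are large and show how far the number can move with a single group on this ring. The third step, a 1.5-fold lower number from compound 1 to compound 2 (0.18 log units; within the scatter), shows less movement. None of these steps adds a group in place of hydrogen, so the size of the new step is poorly constrained. A modest move in this assay towards a higher number is expected, possibly no larger than the scatter, and a wide range is warranted. The expected change is a 1.9-fold higher number from compound 3 to compound 4 (0.27 log units; within the scatter). For compound 4 the estimated value is 90 nM, with an expected range from 20 nM to 500 nM.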

Compound 4, half-maximal inhibitory concentration: 261 nM
For compound 4 the middle estimate is 2.9-fold (0.46 log units) below the measured one; measured number inside the range.
By their numbers in this assay, from the lowest: compound 3; then compound 4; then compounds 2 and 1 (each within the scatter of the next).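

In this assay, within the data shown here, compound 4 gives the first step in this set that puts a group in place of hydrogen on this ring, and adding the second methyl weakens inhibition beyond the scatter (a 5.4-fold higher number from compound 3 to compound 4 (0.74 log units; beyond the scatter)). The 3,4-dimethylphenyl group nevertheless stays well ahead of the halogen-bearing groups (a 13-fold lower number from compound 2 to compound 4 (1.11 log units; beyond the scatter); a 19-fold lower number from compound 1 to compound 4 (1.28 log units; beyond the scatter)), so only part of the advantage seen with 4-methylphenyl is lost. Nothing available explains why this added methyl raises the number.

Open, going by these compounds, is whether a hydroxyl, an amine or a methoxy on the same aromatic carbon would raise the number as this methyl does. Among these compounds, also open is whether an ethyl in place of the single methyl of compound 3 would hold its activity.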